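The source may hold more compounds than are shown below. What is called first, only, known or untested is meant among the compounds shown, and "the series" means these compounds.

Series notes, the step from compound 2 to compound 3.

Two compounds of the shared core carry a number in an assay on Sf9 cells for inhibition of Leucine-rich repeat serine/threonine-protein kinase 2 (Homo sapiens), read by TR-FRET, with stated times of 30 min and 2 h (on this read-out higher numbers stand for weaker inhibition and lower numbers for stronger inhibition), so far. Compound 1 `CN1CC2(C1)CN(c1ccc(OCc3ccccc3)c(C(=O)Nc3ccnnc3)c1)C2` gives 25.1 nM in this assay. Going by the values given here, compound 2 `C[C@@H]1CN(c2ccc(OCc3ccccc3)c(C(=O)Nc3ccnnc3)c2)C[C@H](C)O1` gives 20 nM in this assay, and the two sit within the scatter of each other: the only measured step, a 1.3-fold lower number from compound 1 to compound 2 (0.10 log units; within the scatter), is a swap of one saturated ring of eight heavy atoms for another on the same aromatic carbon.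

Compound 3 `N#CC1CCN(c2ccc(OCc3ccccc3)c(C(=O)Nc3ccnnc3)c2)CC1` is the next member, not yet measured. Its change from compound 2 is 4-cyanopiperidin-1-yl in place of 2,6-dimethylmorpholin-4-yl on an aromatic carbon. Among the compounds with values here, the one step that bears on it, a 1.3-fold lower number from compound 1 to compound 2 (0.10 log units; within the scatter), exchanged groups of the same size at the same place and moved the number by less than the scatter. On that basis no step beyond the scatter is expected in this assay for compound 3, in either direction.

Compound 3 is therefore estimated at 22 nM in this assay, within 8 nM to 60 nM, an expected step of a 1.1-fold higher number from compound 2 to compound 3 (0.04 log units; within the scatter).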

Compound 3, half-maximal inhibitory concentration in the Leucine-rich repeat serine/threonine-protein kinase 2 assay: 10 nM
For compound 3 the middle estimate is 2.2-fold (0.34 log units) above the measured one; measured number inside the range.
By their numbers in the Leucine-rich repeat serine/threonine-protein kinase 2 assay, from the lowest: compounds 3, 2 and 1 (each within the scatter of the next, the first and the last beyond it).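

Going by these compounds alone, in the Leucine-rich repeat serine/threonine-protein kinase 2 assay the change to 4-cyanopiperidin-1-yl on this aromatic carbon gives a 2.0-fold lower number from compound 2 to compound 3 (0.30 log units; within the scatter), so no difference can be claimed for that swap, while the comparison with the spirocyclic group gives a 2.5-fold lower number from compound 1 to compound 3 (0.40 log units; beyond the scatter), the first step beyond the scatter, though a modest one. In a physicochemical assay for lipophilicity, at pH 7.4 (on this read-out lower numbers stand for lower lipophilicity and higher numbers for higher lipophilicity), compound 2 gives 5.4 and compound 3 gives 4.5. In the physicochemical assay that gap is a number 0.90 log units lower from compound 2 to compound 3 (beyond the scatter), so this change moves that read-out beyond the scatter without a step beyond the scatter from the 2,6-dimethylmorpholin-4-yl compound in the inhibition read-out.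

The compounds shown leave open how much of this belongs to the nitrile rather than to the rest of the 4-cyanopiperidin-1-yl group. On these data alone, whether a primary amine or a carboxylic acid in place of the nitrile would hold both numbers also remains open.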